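Iodo for Ethynyl on the Methoxy-Bearing Core

The source may hold more compounds than are shown below. What is called first, only, known or untested is meant among the compounds shown, and "the series" means these compounds.

Three compounds were measured in a functional assay on K562 cells (Homo sapiens), read by MTT assay, with a stated time of 72 h; on this read-out higher numbers stand for weaker inhibition and lower numbers for stronger inhibition. Compound 1 `Cc1ncnc2c1c(I)cn2[C@@H]1O[C@H](CO)[C@@H](O)[C@H]1O` gives 17800 nM, compound 2 `C#Cc1cn([C@@H]2O[C@H](CO)[C@@H](O)[C@H]2O)c2ncnc(C)c12` gives 6920 nM, and compound 3 `C#Cc1cn([C@@H]2O[C@H](CO)[C@@H](O)[C@H]2O)c2ncnc(OC)c12` gives 300 nM. Compound 2 and compound 3 differ in their cores: methoxy in place of methyl on an aromatic carbon, which brought a 23-fold lower number from compound 2 to compound 3 (1.36 log units; beyond the scatter). Compound 1 differs from compound 2 by iodo in place of ethynyl on an aromatic carbon, and that change gave a 2.6-fold higher number from compound 2 to compound 1 (0.41 log units; beyond the scatter). Compound 4 `COc1ncnc2c1c(I)cn2[C@@H]1O[C@H](CO)[C@@H](O)[C@H]1O` carries the same kind of change on the core of compound 3: iodo in place of ethynyl on an aromatic carbon. For the measured compounds named here, the place is described in the same words in both cases, so the earlier step is the only guide available. Compound 4 is therefore expected to show a 2.7-fold higher number from compound 3 to compound 4 (0.43 log units; beyond the scatter) in this assay, an expectation resting on a 2.6-fold higher number from compound 2 to compound 1 (0.41 log units; beyond the scatter). Compound 4 is estimated at 800 nM, with a likely range from 350 nM to 2000 nM.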

Compound 4, half-maximal inhibitory concentration: > 20000 nM
Compound 4: no number, only a limit; the forecaster's own chance of this, stated with the estimate: 2%; middle value at least 25-fold (1.39 log units) away from the limit.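

In this assay compound 4 gives > 20000 nM, which is a limit of the assay and not a number. On the methoxy-bearing core, iodo in place of ethynyl brought an at least 66-fold higher number from compound 3 to compound 4 (1.82 log units; beyond the scatter), so the step did not carry over in size from the methyl-bearing core: the same change on two cores in this assay, a 2.6-fold higher number (0.41 log units; beyond the scatter) from compound 2 to compound 1 and an at least 66-fold higher number (1.82 log units; beyond the scatter) from compound 3 to compound 4, at least 25-fold (1.41 log units) apart, beyond the scatter of two such steps. The methoxy-for-methyl step, an at least 1.1-fold higher number from compound 1 to compound 4 (0.05 log units; that floor lies within the scatter), likewise did not repeat its gain once iodo replaced ethynyl, which shows that the two changes do not act independently here, but it does not show the true size of either step or the reason for the gap: the same change on two cores in this assay, a 23-fold lower number (1.36 log units; beyond the scatter) from compound 2 to compound 3 and an at least 1.1-fold higher number (0.05 log units; that floor lies within the scatter) from compound 1 to compound 4, at least 25-fold (1.41 log units) apart, beyond the scatter of two such steps.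

The compounds shown leave open whether other groups on that aromatic carbon, such as bromo or a longer alkyne chain, would behave like ethynyl or like iodo. They also leave open how an amine in place of methoxy would fare with either group.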